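A few compounds are considered here, and "the series" means these few. Any claim that something is new, unique, unknown or untested is made for them only; others in the source may bear on it.

Measured in a functional assay on A2780 cells (Homo sapiens) for antiproliferative activity, read by MTT assay, with a stated time of 48 h; a lower number here means a stronger inhibitor, a higher number a weaker inhibitor:
- compound 1 `C=C(c1cc(OC)c(OC)c(OC)c1)c1ccc(OC)cc1NC(=O)CO`: 30 nM
- compound 2 `C=C(c1cc(OC)c(OC)c(OC)c1)c1ccc(OC)c(O)c1NC(=O)CN(C)C`: 90 nM

Compound 2 has the higher of the two numbers at 90 nM, so it is the weaker inhibitor of the pair. Compound 1 lies lower at 30 nM, and the gap is beyond the usual scatter.

The next compound is compound 3 `C=C(c1cc(OC)c(OC)c(OC)c1)c1ccc(OC)c(O)c1NC(=O)CO`, which has hydroxy in place of dimethylamino on a saturated chain carbon bound to a carbonyl carbon. Going by the values given here, no measured pair differs in one place only, so the size of this change has not been seen directly.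

In this assay a moderate move to a lower number is expected, probably just beyond the scatter. This expectation rests on the ((hydroxymethyl)carbonyl)amino group also standing in compound 1, which gives 30 nM. Among the compounds with values here, with only two values, no change at all cannot be excluded.

The expected change is a 3.6-fold lower number from compound 2 to compound 3 (0.56 log units; beyond the scatter).

For compound 3 the estimated value is 25 nM, with an expected range of 7 nM to 90 nM.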

Compound 3, half-maximal inhibitory concentration: 20 nM
Beside the measured number, compound 3's estimate is 1.3-fold (0.10 log units) above it, within the range that was stated.
By their numbers in this assay, from the lowest: compounds 3 and 1 (each within the scatter of the next); then compound 2.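

In this assay the change at the saturated chain carbon bound to a carbonyl carbon can now be read directly: hydroxy in place of dimethylamino gives a 4.5-fold lower number from compound 2 to compound 3 (0.65 log units; beyond the scatter) on a core that carries the aromatic hydroxy. The aromatic carbon can also be read on its own, as hydroxy in place of hydrogen gives a 1.5-fold lower number from compound 1 to compound 3 (0.18 log units; within the scatter) with the ((hydroxymethyl)carbonyl)amino group held constant, so in this pair the added hydroxy has no effect that can be separated from the scatter. No measurement at hand accounts for either step and both remain observations on single pairs.

From the compounds shown here alone, it remains open whether the change from dimethylamino to hydroxy has a similar size on a core with hydrogen on that aromatic carbon, as in compound 1. Also open, going by these compounds, is how a methoxy, a primary amine, a carboxylic acid or a longer chain ending in hydroxy on the saturated chain carbon would read against compound 2 and compound 3.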